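A few compounds are considered here, and "the series" means these few. Any claim that something is new, unique, unknown or untested is made for them only; others in the source may bear on it.

Compound 1 `NC1=NC2(CCSCC2)N(OCCCOc2cc(Cl)c(Cl)cc2Cl)C(N)=N1` and compound 2 `NC1=NC2(CCOCC2)N(OCCCOc2cc(Cl)c(Cl)cc2Cl)C(N)=N1` share the same trichlorophenyl ether side chain but differ in their cores; the difference between the two cores is not broken down here. In a functional assay on HL-60 cells (Homo sapiens) for antiproliferative activity, read by MTT assay, with a stated time of 72 h (on this read-out higher numbers stand for weaker inhibition and lower numbers for stronger inhibition), compound 1 gives 730 nM, while compound 2 gives 2360 nM; this gap lies beyond the usual scatter. Compound 3 `NC1=NC2(CCOCC2)N(OCCCOc2ccccc2Br)C(N)=N1` keeps the core of compound 2 and carries the change (2-bromophenyl in place of 2,4,5-trichlorophenyl on an oxygen on a saturated carbon). In this assay compound 3 gives 610 nM, and the step is a 3.9-fold lower number from compound 2 to compound 3 (0.59 log units; beyond the scatter). Compound 1 and compound 3 stand within the scatter of each other, so nothing can be read into their order.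

Compound 4 `NC1=NC2(CCSCC2)N(OCCCOc2ccccc2Br)C(N)=N1` applies the same change to compound 1: 2-bromophenyl in place of 2,4,5-trichlorophenyl on an oxygen on a saturated carbon. The place where the change is made is described in the same words for both pairs, so this is the same change made on a different core. Within the data shown here, only one example of this change has been measured, so whether it carries over from the core of compound 2 to the core of compound 1 is not known from these data. Compound 4 is expected to show a step of about a 2.9-fold lower number from compound 1 to compound 4 (0.47 log units; beyond the scatter), somewhat smaller than the measured one, because compound 1 already starts lower at 730 nM than compound 2 did. Compound 4 is therefore estimated to give 250 nM in this assay, with a plausible range from 100 nM to 650 nM.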

Compound 4, half-maximal inhibitory concentration: 180 nM
Estimate against measurement, compound 4: 1.4-fold (0.14 log units) above; the measured number falls inside the stated range.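

In this assay, putting 2-bromophenyl in place of 2,4,5-trichlorophenyl on the core of compound 1 gives a 4.1-fold lower number from compound 1 to compound 4 (0.61 log units; beyond the scatter). Set beside the step already seen on the core of compound 2, the new step shows no real difference in size, so on these two cores the change lowers the number by a similar amount, even though the two starting compounds, compound 1 and compound 2, stand apart: the same change on two cores in this assay, a 3.9-fold lower number (0.59 log units; beyond the scatter) from compound 2 to compound 3 and a 4.1-fold lower number (0.61 log units; beyond the scatter) from compound 1 to compound 4, 1.0-fold (0.02 log units) apart, within the scatter of two such steps. Among these compounds, this shows that the change carried over between these two cores in this one assay, but it rests on only two pairs of compounds. It says nothing about any other core or any other assay, and the data do not explain the size of the step.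

The compounds shown leave open whether the step comes from the bromine or from the loss of the chlorine atoms, a question that a plain phenyl or a 2-chlorophenyl ether would bear on directly. They also leave open whether the step would hold on a core with an amine in place of the sulfur or oxygen, or on compounds with a longer chain carrying the aryl ether.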